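This account rests on a few compounds, and the source may have more. Where it says the series, first, only, none or still open, it means among the compounds named here.

Of the compounds shown here, two have been measured so far in a physicochemical assay for solubility, measured as kinetic solubility, at pH 2; on this read-out higher numbers stand for higher solubility and lower numbers for lower solubility. Compound 1 `CC(C)C(CC1C(=O)NC(=O)N1C)c1ccc(-c2ccc3cccc(F)c3c2)[nH]c1=O` gives 26600 nM, and compound 2 `CC(C)C(CC1NC(=O)NC1=O)c1ccc(-c2ccc3cccc(F)c3c2)[nH]c1=O` gives 13000 nM, the lower of the two numbers. Going by the values given here, the only measured step puts hydrogen in place of methyl on an amide-type nitrogen in a ring, and it is a 2.0-fold lower number from compound 1 to compound 2 (0.31 log units; beyond the scatter).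

Compound 3 `CC(C)C(c1ccc(-c2ccc3cccc(F)c3c2)[nH]c1=O)C1C(=O)NC(=O)N1C` has not yet been measured. It holds the same atoms as compound 2, joined differently: 3-methyl-2,5-dioxoimidazolidin-4-yl stands in place of (2,5-dioxoimidazolidin-4-yl)methyl on a saturated chain carbon bound to an aromatic carbon and a saturated chain carbon. The count reads (3-methyl-2,5-dioxoimidazolidin-4-yl in place of (2,5-dioxoimidazolidin-4-yl)methyl on a saturated chain carbon bound to an aromatic carbon and a saturated chain carbon).

The measured step bears on this change only in part. Compound 3 carries the ring methyl, as compound 1 does at 26600 nM, but no measurement shows what removing the chain carbon does. A small rise in this assay is expected, no larger than the measured step read in reverse, and it may stay within the scatter. The estimated change is a 1.5-fold higher number from compound 2 to compound 3 (0.19 log units; within the scatter). Compound 3 is expected at 20000 nM, with an estimated range of 7000 nM to 55000 nM.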

Compound 3, solubility: 13600 nM
For compound 3 the middle estimate is 1.5-fold (0.17 log units) above the measured one; the range from low to high includes it.
By their numbers in this assay, from the lowest: compounds 2, 3 and 1 (each within the scatter of the next, the first and the last beyond it).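

Moving the ring methyl and removing the chain carbon together, with the same atoms joined differently, gives a 1.0-fold higher number from compound 2 to compound 3 (0.02 log units; within the scatter) in this assay and so leaves the read-out within the scatter, even though the entering 3-methyl-2,5-dioxoimidazolidin-4-yl counts one hydrogen-bond donor fewer than the leaving (2,5-dioxoimidazolidin-4-yl)methyl. With the ring methyl kept in both compounds, removing the chain carbon gives a 2.0-fold lower number from compound 1 to compound 3 (0.29 log units; within the scatter) and is also within the scatter, so this single change shows no clear effect at this position on the chain, although compound 1 and compound 2 do lie beyond the scatter of each other. Nothing available here explains these numbers.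

The compounds shown do not tell what 2,5-dioxoimidazolidin-4-yl without the ring methyl does when it sits directly on this chain carbon, which would separate the two parts of the change from compound 2 to compound 3. They also leave open whether a longer chain carrying the ring, or an amine or a carboxylic acid in place of the ring, would move the read-out beyond the scatter.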